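The source may report more compounds than this note shows. Statements on the series, on what has been measured and on what is new or still open speak of the compounds shown alone.

Working notes on the series.

Three compounds share the methylene lactone core and have been run in a functional assay on COLO 205 cells (Homo sapiens) for activation, read by flow cytometry, with a stated time of 24 h, tested at 100 uM; a lower number here means a weaker effect, a higher number a stronger effect of the compound at the concentration tested. Compound 1 `C=C1C(=O)O[C@@H]2CC(C)=C([C@@H](C)CCCOC(C)=O)[C@H](OC(C)=O)[C@H]12`, carrying two acetates, gives 17.8%. Compound 2 `C=C1C(=O)O[C@@H]2CC(C)=C([C@@H](C)CCCO)[C@H](O)[C@H]12`, the free diol, gives 28.3%. Compound 3 `C=C1C(=O)O[C@H]2/C=C(\C)CC/C=C(\C)C[C@H](O)[C@@H]12`, on a different ring framework with a single hydroxy, gives 96.8%.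

Compound 2 stands second highest of the three numbers. Its nearest neighbour is compound 1, which lies lower by a gap beyond the scatter; compound 3 lies far higher, also beyond the scatter.

The next compound to be measured is compound 4 `C=C1C(=O)O[C@@H]2CC(C)=C([C@@H](C)CCCO)[C@H](OC(=O)C(C)CC)[C@H]12`. It differs from compound 2 in one place: (sec-butyl)carbonyl in place of hydrogen on an oxygen on a saturated carbon. The change sits on the ring hydroxy; the chain hydroxy stays free.

Going by the values given here, no step between measured compounds isolates this change. Among the compounds with values here, the only guide is compound 1, whose value of 17.8% is lower than compound 2 with both hydroxy groups acylated. Acylation of only the ring hydroxy in compound 4 is therefore expected to move the number from compound 2 downward at most modestly, with a number 4.3 percentage points lower from compound 2 to compound 4 (within the scatter) as the expected step, possibly within the scatter.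

Compound 4 is expected to give 24% in this assay, within a range of 10% to 42%.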

Compound 4, a percentage reported as activity, at one concentration (the size of the read-out at that concentration, not a potency): 36.2%
Compound 4: middle estimate off by 12.2 percentage points, on the low side; the measured number falls inside the stated range.
By their numbers in this assay, from the lowest: compound 1; then compounds 2 and 4 (each within the scatter of the next); then compound 3.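

In this assay, hydroxy to ((sec-butyl)carbonyl)oxy on this oxygen on a saturated carbon gives a number 7.9 percentage points higher from compound 2 to compound 4 (within the scatter). Going by these compounds alone, this is the first step that isolates a change at this position, and it shows that a free hydroxy there is not needed to keep the read-out of compound 2: the (sec-butyl)carbonyl group, with its 6 heavy atoms, leaves the number within the usual scatter at the one concentration tested. Nothing available bears on why the number holds through this change.

The compounds shown leave open whether the same tolerance extends to other groups on this oxygen, such as a benzoyl group, a methyl ether or an amine-bearing acyl chain, and whether a longer chain than sec-butyl would still keep the number within the scatter of compound 2. They also leave open how the chain hydroxy behaves when it alone is changed to an ester, and whether any of this holds at concentrations other than the one used here.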